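A few compounds are considered here, and "the series" means these few. Any claim that something is new, unique, unknown or untested is made for them only; others in the source may bear on it.

In a functional assay on BXPC-3 cells (Homo sapiens) for cytotoxicity, read by MTT assay, with a stated time of 72 h (a lower number here means a stronger inhibitor, a higher number a weaker inhibitor), compound 2 (`O=C(c1ccc(F)cc1)c1cccc(/C=c2\[nH]c(=O)/c(=C/c3c[nH]cn3)[nH]c2=O)c1`) gives 4.3 nM and stands highest of the two measured compounds, while compound 1 (`CC(C)(C)c1[nH]cnc1/C=c1\[nH]c(=O)/c(=C/c2cccc(C(=O)c3ccc(F)cc3)c2)[nH]c1=O`) gives 0.6 nM on the lower side. The next change leads to compound 3 (`Cc1ccc(/C=c2\[nH]c(=O)/c(=C/c3cccc(C(=O)c4ccc(F)cc4)c3)[nH]c2=O)o1`), with 5-methylfuran-2-yl in place of 1H-imidazol-4-yl on a double-bonded chain carbon bound to an aromatic carbon. For the measured compounds named here, the one measured step that bears on this is a 7.2-fold higher number from compound 1 to compound 2 (0.86 log units; beyond the scatter) for hydrogen in place of tert-butyl on an aromatic carbon of that same 1H-imidazol-4-yl ring. It shows that the number in this assay moves when this ring is altered, though only modestly. Going by the values given here, no measured compound carries 5-methylfuran-2-yl, so that size is only a loose guide, and the direction of any change is uncertain. A smaller step is expected, estimated as a 1.9-fold higher number from compound 2 to compound 3 (0.27 log units; within the scatter) in this assay with a slight lean toward a higher number. The estimate for compound 3 is 8 nM and its value is expected to fall from 2 nM to 40 nM.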

Compound 3, half-maximal inhibitory concentration: 3.7 nM
Beside the measured number, compound 3's estimate is 2.2-fold (0.33 log units) above it, and the stated range covers the measured number.
By their numbers in this assay, from the lowest: compound 1; then compounds 3 and 2 (each within the scatter of the next).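

In this assay, the change to 5-methylfuran-2-yl on a double-bonded chain carbon bound to an aromatic carbon is a 1.2-fold lower number from compound 2 to compound 3 (0.07 log units; within the scatter) and lies within the scatter, so compound 2 and compound 3 cannot be told apart, although the entering ring has 0 hydrogen-bond donors and an oxygen where the leaving ring has 1 donor and two nitrogens. The replacement of 5-(tert-butyl)-1H-imidazol-4-yl by 5-methylfuran-2-yl is a 6.2-fold higher number from compound 1 to compound 3 (0.79 log units; beyond the scatter) and lies beyond the scatter, so among these three compounds only compound 1, with its tert-butyl group, stands apart from the other two. Nothing available gives a reason for either step.

Still open, as far as these compounds go, is whether a tert-butyl group in place of the methyl of 5-methylfuran-2-yl would bring the number close to that of compound 1 (0.6 nM), which would tie the difference to that group and not to the ring that carries it. Also open, from the compounds shown here alone, is whether a ring bearing an amine or a carboxylic acid, or an open alkyl chain, would be tolerated at this place.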